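The source may report more compounds than this note shows. Statements on the series, on what has been measured and on what is new or still open speak of the compounds shown alone.

Of the compounds shown here, three on a shared core have been read in a functional assay on MCF7 cells (Homo sapiens) for inhibition, read by sulforhodamine B assay (a lower number here means a stronger inhibitor, a higher number a weaker inhibitor), and only one gives a number. Compound 1 `CCCc1ccc(NC2=CC(=O)c3nc4n(c3C2=O)[C@H]2OC[C@@H](O)[C@H]2OC4)cc1` gives 4660 nM. Compound 2 `O=C1C=C(N2CCC2)C(=O)c2c1nc1n2[C@H]2OC[C@@H](O)[C@H]2OC1` reports > 16000 nM, which is a limit of the assay. Compound 3 `O=C1C=C(NC2CCCCC2)C(=O)c2c1nc1n2[C@H]2OC[C@@H](O)[C@H]2OC1` reports > 8000 nM, which is also a limit and not a number. Compound 3 therefore has no measured position of its own, and between the two limits there is only a step that the two limits leave unreadable from compound 2 to compound 3.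

Compound 4 `CCc1ccc(NC2=CC(=O)c3nc4n(c3C2=O)[C@H]2OC[C@@H](O)[C@H]2OC4)cc1` differs from compound 3 in one place: 4-ethylphenyl in place of cyclohexyl on an amine nitrogen. In words, 4-ethylphenyl stands in place of cyclohexyl on an amine nitrogen.

The measured step that bears on this change is an at least 1.7-fold higher number from compound 1 to compound 3 (0.23 log units; that floor lies within the scatter). There, cyclohexyl enters where 4-propylphenyl leaves, whereas here cyclohexyl leaves and 4-ethylphenyl enters, so the change runs the opposite way with a different group on the ring. That step gives only a floor, and it does not show how large the gap really is. A modest move to a lower number in this assay is therefore expected, though a result at a limit remains possible. The expected change is an at least 1.3-fold lower number from compound 3 to compound 4 (0.12 log units; that floor lies within the scatter). For compound 4 the estimated value is 6000 nM, with an expected range from 2500 nM to 14000 nM.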

Compound 4, half-maximal inhibitory concentration: 960 nM
Compound 4: the middle estimate sits 6.3-fold (0.80 log units) above what was measured; the measured number lies below the stated range.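

With compound 4 at 960 nM in this assay, this amine nitrogen proves able to carry a group that lifts the series well clear of the cyclohexyl result, with an at least 8.3-fold lower number from compound 3 to compound 4 (0.92 log units; beyond the scatter). The earlier pair gave only a floor within the scatter. The same holds for the whole group on the double-bonded ring carbon, where (4-ethylphenyl)amino replaces azetidin-1-yl with an at least 16-fold lower number from compound 2 to compound 4 (1.22 log units; beyond the scatter), and the chain on the aromatic ring also counts, as ethyl in place of propyl gives a 4.9-fold lower number from compound 1 to compound 4 (0.69 log units; beyond the scatter). Compound 3 stands at a limit, so its step is a floor only: the limit of > 8000 nM in this assay, at which 1 of the 4 values shown sits.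

Compound 2 also stands at a limit, so the true size of its step remains open as well: the limit of > 16000 nM in this assay, at which 1 of the 4 values shown sits. Whether a methyl group, a bare phenyl ring or a methoxy group on that ring would move the number further also remains open, as does any cause for the gain.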